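Compound 4 and the methyl on an oxygen

This account rests on a few compounds, and the source may have more. Where it says the series, first, only, none or still open, it means among the compounds named here.

In a functional assay on MCF-A cells (Homo sapiens) for cytotoxicity (on this read-out higher numbers stand for weaker inhibition of growth and lower numbers for stronger inhibition of growth), compound 1 (`COc1ccc(C2=C(c3ccc(SC)cc3)CC3CCCN3C2=O)cc1O`) gives 5000 nM, compound 2 (`COc1ccc(C2=C(c3ccc(SC)cc3)CC3CCCN3C2=O)cc1Br`) gives 6000 nM and compound 3 (`CSc1ccc(C2=C(c3ccc(O)c(O)c3)C(=O)N3CCCC3C2)cc1`) gives 80000 nM. Compound 4 (`CSc1ccc(C2=C(c3ccc(O)cc3)C(=O)N3CCCC3C2)cc1`) differs from compound 1 as follows: 4-hydroxyphenyl in place of 3-hydroxy-4-methoxyphenyl on a double-bonded ring carbon. Exchanging the hydroxy group for bromo left the number nearly unmoved, with a 1.2-fold higher number from compound 1 to compound 2 (0.08 log units; within the scatter). Going by the values given here, compound 3 is the only measured compound without a methyl on an oxygen, and it shows a 16-fold higher number from compound 1 to compound 3 (1.20 log units; beyond the scatter) and a 13-fold higher number from compound 2 to compound 3 (1.12 log units; beyond the scatter). Compound 4 also lacks that methyl, so a higher number, meaning weaker inhibition of growth, is expected. The expected step, somewhat smaller than the largest seen, is a 5.0-fold higher number from compound 1 to compound 4 (0.70 log units; beyond the scatter). For compound 4 the estimated value is 25000 nM, with an expected range from 7000 nM to 80000 nM.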

Compound 4, concentration for 50% growth inhibition: > 100000 nM
Compound 4: only a limit was reported (the forecaster's own chance of this, stated with the estimate: 10%); middle value at least 4.0-fold (0.60 log units) from the limit.
By their numbers in this assay, from the lowest: compounds 1 and 2 (each within the scatter of the next); then compound 3. At a limit, above all of these: compound 4.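

Compound 4 stands at a limit of the assay, not at a number: the limit of > 100000 nM in this assay, at which 1 of the 4 values shown sits. On the double-bonded ring carbon, 4-hydroxyphenyl gives an at least 20-fold higher number from compound 1 to compound 4 (1.30 log units; beyond the scatter) and an at least 16-fold higher number from compound 2 to compound 4 (1.22 log units; beyond the scatter), so the loss seen with compound 3 also appears with a single hydroxy group and no methyl on an oxygen. Hydrogen in place of hydroxy gives an at least 1.2-fold higher number from compound 3 to compound 4 (0.09 log units; that floor lies within the scatter), a floor that does not separate compound 3 from compound 4. The compounds shown leave open whether an ethoxy group or an amine in place of the methoxy group would retain the growth inhibition of compound 1.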